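A few compounds are considered here, and "the series" means these few. Any claim that something is new, unique, unknown or untested is made for them only; others in the source may bear on it.

Compound 1 `C=C1CC[C@@H]2[C@](C)(CO)[C@H](O)CC[C@@]2(C)[C@@H]1C/C=C1/C(=O)OC[C@@H]1Oc1cccc2cccnc12`: 22700 nM
Compound 2 `C=C1CC[C@@H]2[C@](C)(CO)[C@H](O)CC[C@@]2(C)[C@@H]1C/C=C1/C(=O)OC[C@@H]1Oc1c(Cl)cc(Cl)c2cccnc12`: a limit, > 100000 nM
Compound 3 `C=C1CC[C@H]2[C@@](C)(CCC(=O)[C@@]2(C)COC(C)=O)[C@@H]1C/C=C1/C(=O)OC[C@@H]1Oc1c(Cl)cc(Cl)c2cccnc12`: 72000 nM

Of the compounds shown here, three have been measured in an ADME assay on SNB-19 cells (Homo sapiens) for cytotoxicity, read by MTT assay, with a stated time of 24 h; a higher number here means that more compound is tolerated, a lower number that less compound is tolerated. Compound 1 gives 22700 nM. Compound 2 reaches only a limit of this assay, > 100000 nM. Compound 3 gives 72000 nM. Compound 4 `C=C1CC[C@H]2[C@@](C)(CCC(=O)[C@@]2(C)COC(C)=O)[C@@H]1C/C=C1/C(=O)OC[C@@H]1Oc1cccc2cccnc12` has not yet been measured.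

The change from compound 2 to compound 1 is quinolin-8-yl in place of 5,7-dichloroquinolin-8-yl on an oxygen on a saturated carbon. It gave an at least 4.4-fold lower number from compound 2 to compound 1 (0.64 log units; beyond the scatter); the size of that step is bounded because compound 2 sits at the limit of > 100000 nM in this assay, at which 1 of the 3 values shown sits. The same change carries compound 3 into compound 4: quinolin-8-yl in place of 5,7-dichloroquinolin-8-yl on an oxygen on a saturated carbon. How the core of compound 3 differs from the core of compound 2 is not broken down here.

Since the change is the same, a step of similar size is expected, a 4.0-fold lower number from compound 3 to compound 4 (0.60 log units; beyond the scatter). This expectation rests on compound 3 at 72000 nM and on an at least 4.4-fold lower number from compound 2 to compound 1 (0.64 log units; beyond the scatter). Compound 4 is therefore estimated at 18000 nM, expected between 8000 nM and 45000 nM.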

Compound 4, half-maximal cytotoxic concentration: 21900 nM
The estimate for compound 4 lay 1.2-fold (0.09 log units) below the measured number, and the stated range covers the measured number.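

In this assay, putting quinolin-8-yl in place of 5,7-dichloroquinolin-8-yl again gives a lower number, a 3.3-fold lower number from compound 3 to compound 4 (0.52 log units; beyond the scatter), so on these two cores the change runs in the same direction. This does not show that the step keeps its size from one core to the other: the same change on two cores in this assay, an at least 4.4-fold lower number (0.64 log units; beyond the scatter) from compound 2 to compound 1 and a 3.3-fold lower number (0.52 log units; beyond the scatter) from compound 3 to compound 4; the limit leaves it open whether they differ The earlier step has no exact size, since compound 2 stands at a limit and not at a number: the limit of > 100000 nM in this assay, at which 1 of the 4 values shown sits.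

The compounds shown leave open whether the direction holds on any further core. They also leave open where the number would fall with a single chlorine on the quinolin-8-yl group, or with an amine in place of the chlorines.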